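The source may report more compounds than this note shows. Statements on the series, on what has been measured and on what is new or still open speak of the compounds shown alone.

Compound 1 `CC(=O)c1cc(-c2ccc(F)cc2)cc2cc(-c3ccccc3)[nH]c12` — 82.7%
Compound 2 `CC(=O)c1cc(/C=C/c2ccccc2)cc2cc(-c3ccccc3)[nH]c12` — 79.8%

In a functional assay on HeLa cells (Homo sapiens) for cytotoxicity, read by MTT assay, with a stated time of 2 days, tested at 1 uM (a higher number here means a weaker effect of the compound at the concentration tested, a lower number a stronger effect), compound 2 gives 79.8%, the lowest of the two numbers recorded, though the step of a number 2.9 percentage points lower from compound 1 to compound 2 (within the scatter) is within the scatter. Compound 3 `CC(=O)c1cc(/C=C/c2ccc(F)cc2)cc2cc(-c3ccccc3)[nH]c12` differs from compound 2 by fluoro in place of hydrogen on an aromatic carbon. Going by the values given here, no measured step bears directly on this change: the one step recorded swaps the whole aryl group for a styryl group and was itself within the scatter, so no shift beyond the scatter is expected in this assay. For compound 3 the expectation in this assay is 79%, between 66% and 92%, a step of a number 0.8 percentage points lower from compound 2 to compound 3 (within the scatter) from compound 2.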

Compound 3, a percentage reported as activity, at one concentration (the size of the read-out at that concentration, not a potency): 70%
For compound 3 the middle estimate is 9 percentage points above the measured one; the measured number falls inside the stated range.
By their numbers in this assay, from the lowest: compounds 3, 2 and 1 (each within the scatter of the next, the first and the last beyond it).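

In this assay the fluoro on the 2-phenylethenyl group gives a number 9.8 percentage points lower from compound 2 to compound 3 (within the scatter) and so cannot be told from the scatter on its own. Going by these compounds alone, compound 3 nonetheless provides the first step to pass the scatter, with 2-(4-fluorophenyl)ethenyl in place of 4-fluorophenyl giving a number 12.7 percentage points lower from compound 1 to compound 3 (beyond the scatter) at this aromatic carbon. Nothing on hand explains either step. Open, going by these compounds, is whether a methoxy group, an amine or a carboxylic acid in place of the fluoro would move the number beyond the scatter from compound 2.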